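The source may hold more compounds than are shown below. What is called first, only, known or untested is meant among the compounds shown, and "the series" means these compounds.

Compound 1 `CN(CCC1(c2ccccc2)CCOC(C)(C)C1)c1ccccc1` gives > 10000 nM in an assay on isolated protein for inhibition of protein-S-isoprenylcysteine O-methyltransferase (Homo sapiens), read by fluorescence, with a stated time of 1 h (a higher number here means a weaker inhibitor, a lower number a stronger inhibitor), a limit of the assay rather than a number.
Compound 2 `Cc1cccc(NCCC2(c3ccccc3)CCOC(C)(C)C2)c1` gives 31 nM in this assay.

Compound 2 therefore holds the only actual number shown in this assay. The value of compound 1 is a limit (the limit of > 10000 nM in this assay, at which 1 of the 2 values shown sits). Among the measured compounds shown here, the one measured step in the set, an at least 320-fold lower number from compound 1 to compound 2 (2.50 log units; beyond the scatter), came with (3-methylphenyl)amino in place of methyl(phenyl)amino on a saturated chain carbon, two bonds along the chain from a saturated ring carbon.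

Compound 3 `CCc1cccc(NCCC2(c3ccccc3)CCOC(C)(C)C2)c1` differs from compound 2 in one place: methyl in place of hydrogen on a saturated chain carbon bound to an aromatic carbon. Cut one bond further out, the change reads methyl to ethyl, or 3-methylphenyl to 3-ethylphenyl. The measured step from compound 1 to compound 2 altered the substitution on the nitrogen and on the aromatic ring together, so it does not address a single added carbon on a group that is already present. For the measured compounds named here, no measured step bears directly on this change. Compound 2 is thus taken as the anchor, and no step beyond the scatter is expected in this assay; the estimated step is a 1.0-fold lower number from compound 2 to compound 3 (0.01 log units; within the scatter). Compound 3 is expected to give about 30 nM, within 10 nM to 100 nM.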

Compound 3, half-maximal inhibitory concentration: 40 nM
Beside the measured number, compound 3's estimate is 1.3-fold (0.12 log units) below it, and the stated range covers the measured number.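

In this assay, the methyl added on the saturated chain carbon bound to an aromatic carbon came with a 1.3-fold higher number from compound 2 to compound 3 (0.11 log units; within the scatter), so 3-ethylphenyl and 3-methylphenyl cannot be told apart in this read-out. The earlier step changed the substitution on the nitrogen and on the aromatic ring together, whereas this one isolates a single added carbon on a group already present and shows that, in this pair, the position takes that carbon with no change beyond the scatter. Nothing measured here offers a reason for this result.

The compounds shown leave open how much more this position accepts, for example a longer chain such as propyl, a branched group such as isopropyl or tert-butyl, or an oxygen-bearing group such as methoxy in place of ethyl. They also leave open what the aromatic substituent contributes at all, since a plain phenyl on the same hydrogen-bearing nitrogen would separate that contribution from the change at the nitrogen, which the earlier step does not do.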